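Cytotoxicity notes: aryl swap on the triazole nitrogen

The source may hold more compounds than are shown below. What is called first, only, known or untested is meant among the compounds shown, and "the series" means these compounds.

Two compounds of the series have numbers in a functional assay on U-937 cells (Homo sapiens) for cytotoxicity, read by MTT assay, with a stated time of 24 h; a lower number here means a stronger inhibitor, a higher number a weaker inhibitor. Compound 1 `Nc1nn(Cc2cn(-c3cccc(Cl)c3)nn2)c2nc(-c3ccccc3)cc(C(F)(F)F)c12` gives 32.4 ug/mL. Going by the values given here, compound 2 `Nc1nn(Cc2cn(-c3ccc(O)c([N+](=O)[O-])c3)nn2)c2nc(-c3ccccc3)cc(C(F)(F)F)c12` gives 41.3 ug/mL; this is the highest of the two numbers, its nearest neighbour being compound 1, and the only measured step, a 1.3-fold higher number from compound 1 to compound 2 (0.11 log units; within the scatter), changes the aryl group on the aromatic nitrogen without moving the number beyond the scatter. Compound 3 `Cc1c(Br)cccc1-n1cc(Cn2nc(N)c3c(C(F)(F)F)cc(-c4ccccc4)nc32)nn1` is not yet measured. Its change from compound 2 is 3-bromo-2-methylphenyl in place of 4-hydroxy-3-nitrophenyl on an aromatic nitrogen. Among the compounds with values here, the one step that bears on this is the aryl swap from compound 1 to compound 2, which was small; on that basis no step beyond the scatter is expected in this assay for compound 3, in either direction. Compound 3 is therefore estimated at 35 ug/mL, within 15 ug/mL to 80 ug/mL, which means an expected step of a 1.2-fold lower number from compound 2 to compound 3 (0.07 log units; within the scatter).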

Compound 3, half-maximal inhibitory concentration: 97.2 ug/mL
Estimate against measurement, compound 3: 2.8-fold (0.44 log units) below; the measured number lies above the stated range.
By their numbers in this assay, from the lowest: compounds 1 and 2 (each within the scatter of the next); then compound 3.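

In this assay the aryl group on this aromatic nitrogen can move the number after all: 3-bromo-2-methylphenyl in place of 4-hydroxy-3-nitrophenyl gives a 2.4-fold higher number from compound 2 to compound 3 (0.37 log units; beyond the scatter), and in place of 3-chlorophenyl it gives a 3.0-fold higher number from compound 1 to compound 3 (0.48 log units; beyond the scatter). Going by these compounds alone, these are the only steps beyond the scatter among the three compounds, and both run towards a weaker inhibitor, so compound 3 stands apart from a pair that cannot be told apart. No measured data are at hand that explain this difference.

Going by these compounds, the bromine and the methyl enter together, so which of them carries the step stays open. Also open, on these data alone, is how an aryl group bearing an amine or a carboxylic acid, or a plain alkyl chain on this nitrogen, would read in this assay.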